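The compounds below may be only part of what the source reports. "The series", "measured", "known", "first", "only" and "open" are said of these compounds alone.

Working notes on the series. In a functional assay on K562 cells (Homo sapiens) for antiproliferative activity (on this read-out lower numbers stand for stronger inhibition and higher numbers for weaker inhibition), compound 1 `Nc1n[nH]c(N)c1/N=N/c1cccc([N+](=O)[O-])c1` gives 79000 nM and compound 2 `Nc1n[nH]c(N)c1/N=N/c1ccc([N+](=O)[O-])cc1` gives 71000 nM, two values within the scatter of each other. Compound 3 `Nc1n[nH]c(N)c1/N=N/c1cccc(O)c1` returns only a limit, > 100000 nM. That is the limit of > 100000 nM in this assay, at which 1 of the 3 values shown sits, so compound 3 has no measured number of its own.

The next step leads to compound 4 `Nc1n[nH]c(N)c1/N=N/c1cccc(C(=O)O)c1`, with carboxy in place of hydroxy on an aromatic carbon, meta to a group of 9 heavy atoms: carboxy in place of hydroxy on an aromatic carbon.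

Among the measured compounds shown here, one measured step bears on this change, an at least 1.2-fold higher number from compound 1 to compound 3 (0.10 log units; that floor lies within the scatter), where hydroxy replaces nitro on an aromatic carbon. From the compounds shown here alone, its floor lies within the scatter and its true size is unknown. For the measured compounds named here, no measured compound other than compound 4 carries carboxy, so the data give no direct guide to this group. On that thin basis, no step beyond the scatter is expected in this assay, and weak activity close to the limit of the assay is the expected outcome.

The estimated step is a number no higher from compound 3 to compound 4 (the limit leaves the size open), and a reported limit rather than a number remains quite possible. The expected value for compound 4 is 100000 nM, with an estimated range from 50000 nM to 200000 nM.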

Compound 4, half-maximal inhibitory concentration: > 100000 nM
Compound 4: no number, only a limit; the forecaster's own chance of this, stated with the estimate: 60%; the middle value lies on the limit itself.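

In this assay compound 4 returns only a limit, > 100000 nM, so carboxy gives no measured number on the same aromatic carbon, just as hydroxy gave none, and the limit now recurs in the series: the limit of > 100000 nM in this assay, at which 2 of the 4 values shown sit.

From the compounds shown here alone, replacing nitro with carboxy on that carbon gives an at least 1.2-fold higher number from compound 1 to compound 4 (0.10 log units; that floor lies within the scatter), so this second replacement of nitro also shows no change beyond the scatter, and its true size stays unknown. The step from hydroxy to carboxy cannot be read, as both of its ends are limits, and carboxy and hydroxy therefore cannot be ranked against each other.

The compounds shown leave open whether any group other than nitro on this carbon, such as an amine, a methoxy group or a nitrile, returns a measured number at all in this assay. They also leave open whether carboxy or hydroxy would return a number on the ring carbon that carries nitro in compound 2, and whether any change to the shared core would matter more than these swaps.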